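Three Inactive Amide Analogues and a Fluorinated Fourth

This account rests on a few compounds, and the source may have more. Where it says the series, first, only, none or still open, it means among the compounds named here.

Measured compounds in an ADME assay on L6 cells (Rattus norvegicus) for cytotoxicity, read by resazurin assay, with a stated time of 70 h; a lower number here means a stronger inhibitor, a higher number a weaker inhibitor:
- compound 1 `COc1cc(NC(C)CCCNC(=O)/C(C)=C/c2ccccc2)c2ncccc2c1`: > 250000 nM, a limit of the assay.
- compound 2 `COc1ccc(/C=C/C(=O)NCCCC(C)Nc2cc(OC)cc3cccnc23)cc1`: > 240000 nM, also a limit.
- compound 3 `COc1cc(NC(C)CCCNC(=O)/C=C/c2cc(OC)c(OC)c(OC)c2)c2ncccc2c1`: > 210000 nM, again a limit.

Compound 2 therefore stands only at a limit, as do the other two values, which sit at the limit of > 210000 nM in this assay, at which 1 of the 3 values shown sits, the limit of > 240000 nM in this assay, at which 1 of the 3 values shown sits, and (the limit of > 250000 nM in this assay, at which 1 of the 3 values shown sits). Among the compounds with values here, the one measured step, a step that the two limits leave unreadable from compound 1 to compound 2, cannot be read, since both of its ends are limits.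

Compound 4 `COc1cc(NC(C)CCCNC(=O)/C=C/c2ccccc2F)c2ncccc2c1` differs from compound 2 by 2-fluorophenyl in place of 4-methoxyphenyl on a double-bonded chain carbon bound to a double-bonded chain carbon. Within the data shown here, no measured step bears on this change. Compound 4 is therefore expected to show no step beyond the scatter, a step that the limit leaves unreadable from compound 2 to compound 4, in this assay. The estimate for compound 4 is 250000 nM, within a range from 100000 nM to 500000 nM, most likely reported again as a limit.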

Compound 4, half-maximal inhibitory concentration: 3500 nM
Estimate against measurement, compound 4: 71-fold (1.85 log units) above; the whole stated range lies above it.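

In this assay the swap of 4-methoxyphenyl for 2-fluorophenyl gives an at least 68-fold lower number from compound 2 to compound 4 (1.83 log units; beyond the scatter) and shows that this end of the molecule can change the reading, which three limits could not show. Putting 2-(2-fluorophenyl)ethenyl in place of 1-methyl-2-phenylethenyl on the carbonyl carbon gives an at least 71-fold lower number from compound 1 to compound 4 (1.85 log units; beyond the scatter) and points the same way. Nothing measured here explains these steps.

Going by these compounds, whether they belong to the fluorine itself or to the loss of the methoxy group stays open. A 2-chlorophenyl or 4-fluorophenyl group in the same place would bear on that question.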